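Working notes: compounds 1 and 2, and compound 3

The source may report more compounds than this note shows. Statements on the series, on what has been measured and on what is new or still open speak of the compounds shown alone.

Measured in an assay for binding affinity to Melanocortin receptor 4 (Homo sapiens); on this read-out higher numbers stand for weaker inhibition and lower numbers for stronger inhibition:
- compound 1 `COc1ccc(Br)cc1CCc1c(F)cccc1C(=O)/N=C(\N)NCC(C)C` gives 770 nM
- compound 2 `CCN(CC)CCCC(C)/N=C(/N)NC(=O)c1cccc(F)c1OCc1cc(Br)ccc1OC` gives 900 nM

Compound 1 has the lowest of the two numbers in this assay. Its nearest neighbour is compound 2, whose number is only slightly higher, a gap that sits within the usual scatter, so no order between the two can be read. Compound 2 also differs from compound 1 in more than one place, so nothing can be said of any single change between them.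

Compound 3 `COc1ccc(Br)cc1CCc1c(F)cccc1C(=O)/N=C(\N)NCCN1CCCC1` is to be measured in this assay. It departs from compound 1 in one place: (pyrrolidin-1-yl)methyl in place of isopropyl on a saturated chain carbon bound to an amine nitrogen. Within the data shown here, no comparable step between two measured compounds exists in this set. The expectation for the step from compound 1 to compound 3 is therefore a small one, a 1.4-fold lower number from compound 1 to compound 3 (0.15 log units; within the scatter), not clearly beyond the scatter, and with the direction uncertain. Compound 3 is accordingly estimated at 550 nM, with a range from 150 nM to 2000 nM.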

Compound 3, inhibition constant: 190 nM
Compound 3: middle estimate off by 2.9-fold (0.46 log units), on the high side, and the stated range covers the measured number.
By their numbers in this assay, from the lowest: compound 3; then compounds 1 and 2 (each within the scatter of the next).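

In this assay, (pyrrolidin-1-yl)methyl in place of isopropyl on a saturated chain carbon bound to an amine nitrogen gives a 4.1-fold lower number from compound 1 to compound 3 (0.61 log units; beyond the scatter). This position on the core of compound 1 therefore responds to the choice of group, which the earlier pair, differing in more than one place, could not show. The change brings in a nitrogen and a five-membered non-aromatic ring together, and no information is available to account for the step.

From the compounds shown here alone, it remains open whether the lower number follows the amine nitrogen, the ring or the greater size of the entering group. On the same core, a dimethylamino group or a piperidine ring at the end of the chain, or a longer chain carrying the pyrrolidine ring, would help to separate these.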